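The source may hold more compounds than are shown below. What is called first, only, known or untested is meant among the compounds shown, and "the series" means these compounds.

Compound 1, `CCCCCCc1cn([C@H]2C[C@@H]3OP(=O)(O)OC[C@H]3O2)c(=O)[nH]c1=O`, in a functional assay on Raji cells (Homo sapiens) (on this read-out lower numbers stand for stronger inhibition and higher numbers for weaker inhibition), gives > 500 ug/mL.
Compound 2, `CCCc1cn([C@H]2C[C@@H]3OP(=O)(O)OC[C@H]3O2)c(=O)[nH]c1=O`, in this assay gives > 500 ug/mL.

The value for compound 1 is a limit of the assay, not a number. The value for compound 2 is likewise a limit of the assay, not a number. Compound 2 therefore stands at the top of what the assay can report, and it shares that position: the limit of > 500 ug/mL in this assay, at which 2 of the 2 values shown sit. Between them lies a step that the two limits leave unreadable from compound 1 to compound 2, so the one measured step gives no readable size and no direction.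

Compound 3, `CC(C)c1cn([C@H]2C[C@@H]3OP(=O)(O)OC[C@H]3O2)c(=O)[nH]c1=O`, differs from compound 2 by isopropyl in place of propyl on an aromatic carbon. The two compounds are built from the same atoms, joined differently. Going by the values given here, the only measured step, from compound 1 to compound 2, bears on this change but cannot be read, so there is no basis to expect a move beyond the scatter in either direction. On that footing compound 3 is expected to give about 800 ug/mL in this assay, within 300 ug/mL to 3000 ug/mL. The expected step is a step that the limit leaves unreadable from compound 2 to compound 3, and the assay is expected to report only a limit again.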

Compound 3, concentration for 50% inhibition: > 500 ug/mL
Compound 3 ended at the assay's limit; the forecaster's own chance of this, stated with the estimate: 85%; the middle value is on the limit's open side.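

Going by these compounds alone, no step among compound 1, compound 2 and compound 3 can be read, since each value is a limit of the assay and not a number: the limit of > 500 ug/mL in this assay, at which 3 of the 3 values shown sit.
The compounds shown leave open whether hexyl, propyl and isopropyl on the shared core differ at all in this assay and what actual number any of them would give.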